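The source may report more compounds than this note shows. Statements on the series, on what has been measured and on what is new or still open speak of the compounds shown alone.

Compounds measured so far in an assay on isolated protein for antagonist activity at Bile acid receptor (Homo sapiens), read by HTRF, with a stated time of 30 min; on this read-out lower numbers stand for stronger inhibition and higher numbers for weaker inhibition:

Compound 1 `CC(C)(C)c1cc(OC(=O)c2ccco2)ccc1O` — in this assay compound 1 gives > 100000 nM, which is a limit of the assay and not a number.
Compound 2 `Cc1ccccc1C(=O)Oc1ccc(O)c(C(C)(C)C)c1` — in this assay compound 2 gives > 100000 nM, also a limit of the assay.
Compound 3 `CC(C)(C)c1cc(NC(=O)c2ccc(Cl)cc2Cl)ccc1O` — in this assay compound 3 gives 13600 nM.

Compound 3 is thus the only one of the three for which a number, rather than a limit, is reported; the other two sit at the limit of > 100000 nM in this assay, at which 2 of the 3 values shown sit. Among the compounds with values here, the single step between measured compounds, a step that the two limits leave unreadable from compound 1 to compound 2, runs between two limits and its size cannot be read.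

Compound 4 `CC(C)(C)c1cc(NC(=O)c2ccc(Cl)cc2Cl)cc(C(C)(C)C)c1O` differs from compound 3 in one place: tert-butyl in place of hydrogen on an aromatic carbon. Within the data shown here, no measured step involves a change of this kind, and the one step that is available is unreadable, so nothing in the data points to a direction for this change in this assay. The expectation for compound 4 therefore rests on compound 3 alone, with wide uncertainty, and the estimated step of a 1.1-fold lower number from compound 3 to compound 4 (0.05 log units; within the scatter) is taken to lie within the scatter. Compound 4 is accordingly expected to give about 12000 nM in this assay, with a likely range from 2500 nM to 60000 nM.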

Compound 4, half-maximal inhibitory concentration: > 100000 nM
Compound 4: no number, only a limit; the forecaster's own chance of this, stated with the estimate: 25%; middle value at least 8.3-fold (0.92 log units) from the limit.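

In this assay, compound 4 sits at > 100000 nM, which is a limit of the assay and not a number. Placing tert-butyl on the aromatic carbon ortho to a hydroxy group, where compound 3 carries hydrogen, gives an at least 7.3-fold higher number from compound 3 to compound 4 (0.86 log units; beyond the scatter); this is the first readable step among the compounds shown, and it shows that this position does not accept this change without a loss of measurable inhibition, at least on the amide shared by this pair. The result also leaves compound 3 as the only compound with a number, while the limit now covers most of the set: the limit of > 100000 nM in this assay, at which 3 of the 4 values shown sit.

The compounds shown leave open whether a smaller group at this position, such as methyl or a chlorine atom, or a group such as an amine or a carboxylic acid, would keep inhibition at the level of compound 3. Going by these compounds, they also leave open how far the true value of compound 4 lies from its limit, so the full size of this step remains unknown.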